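This account rests on a few compounds, and the source may have more. Where it says the series, first, only, none or still open, it means among the compounds named here.

Two measured members of the series carry the same core and differ in the side chain on the pendant ring. Compound 1 `Cn1ccc2ccc(-c3cc(Nc4ccccc4S(=O)(=O)Nc4cncnc4)cc4nccnc34)cc21` gives 254 ug/mL in a physicochemical assay for solubility, read by spectrophotometry, measured as kinetic solubility, at pH 8, tested at 500 uM; on this read-out higher numbers stand for higher solubility and lower numbers for lower solubility. Compound 2 `Cn1ccc2ccc(-c3cc(Nc4cnccc4C(=O)NCc4cncnc4)cc4nccnc34)cc21` gives 233 ug/mL in this assay, a number that sits within the scatter of the value of compound 1, so the two cannot be told apart on this read-out. Compound 3 `CN1CCC(N(C)C(=O)c2ccncc2Nc2cc(-c3ccc4ccn(C)c4c3)c3nccnc3c2)C1` is not yet measured. It differs from compound 2 in one place: methyl(1-methylpyrrolidin-3-yl)amino in place of ((pyrimidin-5-yl)methyl)amino on a carbonyl carbon. Within the data shown here, no measured pair tells what such a change does here. Among the measured compounds shown here, both measured compounds sit at a high level, and with no step to lean on the expectation for compound 3 is a flat one, a step of a 1.0-fold higher number from compound 2 to compound 3 (0.01 log units; within the scatter) that stays within the scatter. Compound 3 is therefore estimated at 240 ug/mL in this assay, with a range of 170 ug/mL to 265 ug/mL.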

Compound 3, solubility: 245 ug/mL
Beside the measured number, compound 3's estimate is 1.0-fold (0.01 log units) below it, within the range that was stated.
By their numbers in this assay, from the lowest: compounds 2, 3 and 1 (each within the scatter of the next).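

At the carbonyl carbon, this assay now has its first measured step, a 1.1-fold higher number from compound 2 to compound 3 (0.02 log units; within the scatter), so this change does not move the read-out beyond the scatter. The exchange is not a small one on paper: a six-membered aromatic ring gives way to a five-membered non-aromatic ring, and the entering methyl(1-methylpyrrolidin-3-yl)amino has 0 hydrogen-bond donors, yet the two compounds cannot be told apart here. No measurement at hand accounts for this flat result.

A single step cannot show whether the read-out stays level across other groups on this carbonyl carbon, such as a morpholine, a dimethylamino group or a longer chain. Going by these compounds, whether a carboxylic acid in this place would separate from these compounds also remains open.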